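Changing the Amide Nitrogen Substituent of a Weak Inhibitor

This account rests on a few compounds, and the source may have more. Where it says the series, first, only, none or still open, it means among the compounds named here.

Measured compounds:
Compound 1: `COc1ccc2c(c1)OC(c1cc(OC)c(OC)c(OC)c1)C(CO)=C2`; in a functional assay for inhibition of nuclear factor NF-kappa-B complex (Homo sapiens) (a lower number here means a stronger inhibitor, a higher number a weaker inhibitor), compound 1 reaches only the assay limit, > 50000 nM.
Compound 2: `COc1ccc2c(c1)OC(c1cc(OC)c(OC)c(OC)c1)C(C(=O)N(C)OC)=C2`; in this assay compound 2 gives 11700 nM.

Within the data shown here, compound 2 stands as the only compound with a genuine number; the other value is a limit (the limit of > 50000 nM in this assay, at which 1 of the 2 values shown sits). Among the measured compounds shown here, the single measured step, an at least 4.2-fold lower number from compound 1 to compound 2 (0.63 log units; beyond the scatter), shows that replacing the hydroxymethyl with an amide moves the compound off the limit into measurable range.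

Compound 3, `COc1ccc2c(c1)OC(c1cc(OC)c(OC)c(OC)c1)C(C(=O)NC(C)C)=C2`, keeps the amide carbonyl of compound 2 and changes only what sits on its nitrogen: isopropylamino in place of methoxy(methyl)amino on a carbonyl carbon. The measured step does not bear directly on this change, since it swapped an alcohol for an amide rather than altering the amide substituents. For the measured compounds named here, with no step that tests this position, the expectation in this assay is a change not beyond the scatter, and compound 3 is estimated to give 12000 nM (range 4000 nM to 40000 nM), meaning an expected step of a 1.0-fold higher number from compound 2 to compound 3 (0.01 log units; within the scatter).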

Compound 3, half-maximal inhibitory concentration: > 50000 nM
Compound 3 was reported as a limit; the forecaster's own chance of this, stated with the estimate: 25%; middle value at least 4.1-fold (0.61 log units) away from the limit.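

The amide carbonyl alone is not enough to keep a measurable result in this assay: with the carbonyl kept and only the group on its nitrogen changed, the result is an at least 4.2-fold higher number from compound 2 to compound 3 (0.63 log units; beyond the scatter). This position, on a carbonyl carbon, therefore responds to what is attached there, and methoxy(methyl)amino gives a measurable value where isopropylamino does not, even though both groups hold the same number of heavy atoms. Compound 1 and compound 3 both end at the assay limit, so the step between them cannot be read, and the series is crowded against the top of the read-out: the limit of > 50000 nM in this assay, at which 2 of the 3 values shown sit.

This one swap removes the oxygen and adds an amide hydrogen at the same time, and the compounds shown cannot separate these two changes, nor say how far past the limit compound 3 really lies. A dimethylamino group on the same carbonyl carbon, which has no amide hydrogen and no oxygen, would help to separate them, and a methoxyamino group, which has both, would test the same question from the other side.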